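The source may report more compounds than this note shows. Statements on the series, on what has been measured and on what is new or still open speak of the compounds shown alone.

In a functional assay on HCT-15 cells (Homo sapiens) for cytotoxicity, read by ELISA, with a stated time of 4 days (a higher number here means a weaker inhibitor, a lower number a stronger inhibitor), compound 1 `Cc1ccc(-c2cc(-c3ccoc3)cc(-c3ccc(Cl)s3)n2)o1` gives 790 nM and compound 2 `Clc1cccc(-c2cc(-c3ccoc3)cc(-c3ccc(Cl)s3)n2)c1` gives 950 nM, so the two stand within the scatter of each other. Compound 3 `Clc1ccc(-c2cc(-c3ccoc3)cc(-c3ccc(Cl)s3)n2)cc1` has not yet been measured. It differs from compound 2 at one place: 4-chlorophenyl in place of 3-chlorophenyl on an aromatic carbon, with 4-chlorophenyl in place of 3-chlorophenyl on an aromatic carbon. Within the data shown here, the only measured step at this place is a 1.2-fold higher number from compound 1 to compound 2 (0.08 log units; within the scatter), with 3-chlorophenyl in place of 5-methylfuran-2-yl, and no step between the two chlorophenyl groups has been measured. Nothing beyond the scatter is therefore expected, and the estimated step is a 1.1-fold lower number from compound 2 to compound 3 (0.02 log units; within the scatter). For compound 3 the expected value is 900 nM, with an estimated range of 400 nM to 2000 nM.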

Compound 3, half-maximal inhibitory concentration: 640 nM
The estimate for compound 3 lay 1.4-fold (0.15 log units) above the measured number; low and high end bracket the measured number.
By their numbers in this assay, from the lowest: compounds 3, 1 and 2 (each within the scatter of the next).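

In this assay the exchange between the two chlorophenyl groups, on the aromatic carbon next to the ring nitrogen, gives a 1.5-fold lower number from compound 2 to compound 3 (0.17 log units; within the scatter) and so leaves the two compounds undistinguished by where the chlorine sits. Placing 4-chlorophenyl in place of 5-methylfuran-2-yl gives a 1.2-fold lower number from compound 1 to compound 3 (0.09 log units; within the scatter) and thus puts all three groups at this position within the scatter of each other. No evidence on the reason for this is available. As far as these compounds go, whether an amine or a carboxylic acid on this phenyl ring would move the number beyond the scatter stays open, as does the effect of replacing the furan-3-yl or 5-chlorothiophen-2-yl group.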